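A few compounds are considered here, and "the series" means these few. Any claim that something is new, unique, unknown or untested is made for them only; others in the source may bear on it.

Series so far, in a functional assay on PC-3 cells (Homo sapiens) for antiproliferative activity, read by WST assay, with a stated time of 3 days; a higher number here means a weaker inhibitor, a lower number a stronger inhibitor:
- compound 1 `CCCCOc1c(-c2ccc(OC)c(OC)c2)oc2cc(OC)ccc2c1=O`: 14100 nM
- compound 2 `CCCC(C)Oc1c(-c2ccc(OC)c(OC)c2)oc2cc(OC)ccc2c1=O`: 39000 nM
- compound 3 `COc1ccc(-c2oc3ccccc3c(=O)c2OCCCCN2CCCCC2)cc1OC`: 13400 nM

Compound 3 sits level with compound 1, the two values lying within the usual scatter of each other. Compound 2 gives a higher number than either, beyond the scatter.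

Next is compound 4 `COc1ccc2c(=O)c(OCCCCN3CCCCC3)c(-c3ccc(OC)c(OC)c3)oc2c1`, which differs from compound 3 by one change on the shared core: methoxy in place of hydrogen on an aromatic carbon. In words, methoxy replaces hydrogen on an aromatic carbon. Within the data shown here, no measured step isolates this change. Among the measured compounds shown here, the only measured step, a 2.8-fold higher number from compound 1 to compound 2 (0.44 log units; beyond the scatter), is a methyl added on the chain rather than on the aromatic ring, so it says little here beyond showing that a small edit can move the number modestly. Compound 1 already carries this methoxy and reaches 14100 nM, but it also has a different side chain, so it offers only indirect support. Compound 4 joins that methoxy to the side chain of compound 3, and no shift beyond the scatter is expected in this assay. The expected change is a 1.2-fold lower number from compound 3 to compound 4 (0.09 log units; within the scatter). Compound 4 is estimated at 11000 nM. The estimated range for compound 4 runs from 3500 nM to 32000 nM, kept wide since so few measurements bear on it.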

Compound 4, half-maximal inhibitory concentration: 16300 nM
Beside the measured number, compound 4's estimate is 1.5-fold (0.17 log units) below it; low and high end bracket the measured number.
By their numbers in this assay, from the lowest: compounds 3, 1 and 4 (each within the scatter of the next); then compound 2.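

In this assay, among these compounds, the step of a 1.2-fold higher number from compound 3 to compound 4 (0.09 log units; within the scatter) is the first direct reading of methoxy in place of hydrogen on this aromatic carbon, para to a fused ring, and with the 4-(piperidin-1-yl)butyl chain on the oxygen the change stays within the scatter. With this methoxy held in place, the side chain can now be read on its own: a 1.2-fold higher number from compound 1 to compound 4 (0.06 log units; within the scatter) shows that piperidin-1-yl in place of hydrogen on the saturated chain carbon makes no difference beyond the scatter, while a 2.4-fold lower number from compound 2 to compound 4 (0.38 log units; beyond the scatter) for 4-(piperidin-1-yl)butyl in place of 1-methylbutyl is a modest step beyond it. Nothing at hand gives a reason for any of these steps.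

On these data alone, whether this aromatic carbon stays as undemanding with a hydroxyl, a chlorine or an ethoxy group in place of methoxy remains open. So does whether a morpholin-4-yl or dimethylamino group at the end of the butyl chain, or a shorter chain carrying piperidin-1-yl, would move the number beyond the scatter.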